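Swapping pyridin-2-yl for furan-2-yl on a shared core

A few compounds are considered here, and "the series" means these few. Any claim that something is new, unique, unknown or untested is made for them only; others in the source may bear on it.

Three compounds have been measured in an assay on CHO cells for displacement of a labelled ligand from adenosine receptor A1 (Homo sapiens), read by scintillation counting, tested at 10 uM; on this read-out lower numbers stand for less inhibition and higher numbers for more inhibition at the one concentration tested (going by the name of the read-out):

Compound 1, `Cc1c(-c2ccccc2)sc(N)c1C(=O)c1ccc(Cl)cc1`, gives 1%.
Compound 2, `CC(C)(C)Cc1c(-c2ccccn2)sc(N)c1C(=O)c1ccc(Cl)cc1`, gives 1%.
Compound 3, `CC(C)(C)Cc1c(-c2ccccc2)sc(N)c1C(=O)c1ccc(Cl)c(Cl)c1`, gives 1%.

Compound 2 stands level with compounds 1 and 3 at the digits shown. Its nearest neighbour is compound 1, with no change at the digits shown, within the scatter; its furthest is compound 3, again with no change at the digits shown, within the scatter. All three read-outs mean barely any inhibition at the single concentration tested.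

Compound 4, `CC(C)(C)Cc1c(-c2ccco2)sc(N)c1C(=O)c1ccc(Cl)cc1`, is not yet measured. Against compound 2 it shows one change: furan-2-yl in place of pyridin-2-yl on an aromatic carbon.

Within the data shown here, no step between two measured compounds is available, so there is no measured change to lean on. Since every measured compound sits at the bottom of the scale, the step is expected to be none beyond the scatter, a number 1 percentage points higher from compound 2 to compound 4 (within the scatter). In this assay compound 4 is therefore estimated to give 2%, with a range from -6% to 12%.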

Compound 4, a percentage reported as inhibition, at one concentration (the size of the read-out at that concentration, not a potency): 1%
For compound 4 the middle estimate is 1 percentage points above the measured one; measured number inside the range.
By their numbers in this assay, from the lowest: compounds 1, 2, 3 and 4 (each within the scatter of the next).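

Among these compounds, this pair gives the first direct one-place comparison: on an aromatic carbon next to the ring sulfur, replacing the six-membered pyridin-2-yl with the five-membered furan-2-yl gives no change at the digits printed from compound 2 to compound 4 (within the scatter) in this assay. Among the compounds shown here, since both compounds sit at the bottom of the scale, the pair shows only that this swap does not bring out inhibition at the single concentration tested, and it cannot show how the swap would act on a compound with clear inhibition. Nothing here offers an explanation for this reading.

From the compounds shown here alone, it remains open whether a different group at this position, such as a carboxylic acid or an aminomethyl group, would read any differently. Going by these compounds, it is also open whether the choice between these two rings matters on a compound that shows clear inhibition.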